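A few compounds are considered here, and "the series" means these few. Any claim that something is new, unique, unknown or untested is made for them only; others in the source may bear on it.

The study compares four compounds in a functional assay on cells (Cancer cell lines, Homo sapiens) for cytotoxicity, read by sulforhodamine B assay, with a stated time of 48 h; a higher number here means a weaker inhibitor of growth, a lower number a stronger inhibitor of growth. Compound 1 `COc1ccc(C2CC(c3ccc4ccccc4c3)=NN2C2=NC(=O)/C(=C3\C(=O)Nc4ccccc43)S2)cc1` gives 4030 nM in this assay. Compound 2 `COc1ccc(C2CC(c3ccc4ccccc4c3)=NN2C2=NC(=O)/C(=C3\C(=O)Nc4ccc(Br)cc43)S2)cc1` carries bromo in place of hydrogen on an aromatic carbon and in this assay compound 2 gives 220 nM, so that the step of an 18-fold lower number from compound 1 to compound 2 (1.26 log units; beyond the scatter) is the one measured effect of this change. Compound 3 `COc1ccc(C2=NN(C3=NC(=O)/C(=C4\C(=O)Nc5ccccc54)S3)C(c3ccc(Cl)cc3)C2)cc1` rests on a different core; the difference between its core and that of compound 1 is not broken down here. In this assay compound 3 gives 100000 nM, the highest number among the three measured compounds, standing far from compound 1 and still further from compound 2.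

Compound 4 `COc1ccc(C2=NN(C3=NC(=O)/C(=C4\C(=O)Nc5ccc(Br)cc54)S3)C(c3ccc(Cl)cc3)C2)cc1` has not yet been measured. Within the data shown here, it differs from compound 3 by bromo in place of hydrogen on an aromatic carbon, the same change, at the same place word for word, as the one separating compound 1 from compound 2. Because the earlier change gave an 18-fold lower number from compound 1 to compound 2 (1.26 log units; beyond the scatter), a drop in number is expected for compound 4 as well. The two cores differ, however, and nothing measured shows whether the change carries over from one core to the other, so the expected step is held smaller than the earlier one and kept broad: the estimated step is a 10-fold lower number from compound 3 to compound 4 (1.00 log units; beyond the scatter). Compound 4 is therefore expected to give about 10000 nM in this assay, with an estimated range from 2000 nM to 60000 nM.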

Compound 4, concentration for total growth inhibition: 340 nM
Compound 4: middle estimate off by 29-fold (1.47 log units), on the high side; the measured number lies below the stated range.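

In this assay, bromo in place of hydrogen on an aromatic carbon again lowers the number, with a 290-fold lower number from compound 3 to compound 4 (2.47 log units; beyond the scatter), so the direction of the change is the same on both cores shown. The size of the step does not carry over, however, and the two steps stand clearly apart: the same change on two cores in this assay, an 18-fold lower number (1.26 log units; beyond the scatter) from compound 1 to compound 2 and a 290-fold lower number (2.47 log units; beyond the scatter) from compound 3 to compound 4, 16-fold (1.21 log units) apart, beyond the scatter of two such steps. Among these compounds, this shows that, in this series, a step measured on one core gave the direction on the other but not the size; with only two pairs, it does not show why the steps differ or how the change would behave on any further core.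

The compounds shown leave open whether another group at the same place, such as chloro, fluoro, methoxy, an amine or a carboxylic acid, would lower the number as bromo does on either core. They also leave open how far the step depends on where bromo sits, since another carbon of the same six-membered aromatic ring could give a different result on each of the two cores.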